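Working notes on compound 3 in the cathepsin S series

A few compounds are considered here, and "the series" means these few. Any claim that something is new, unique, unknown or untested is made for them only; others in the source may bear on it.

Compound 1 `Cc1cc(-c2nn(CC(O)CN3CCC(n4c(O)nc5ccccc54)CC3)c3c2CN(S(C)(=O)=O)CC3)ccc1Cl` and compound 2 `CS(=O)(=O)N1CCc2c(c(-c3ccc(C(F)(F)F)cc3)nn2CC(O)CN2CCC(n3c(O)nc4ccccc43)CC2)C1` share one core. In an assay on isolated protein for inhibition of cathepsin S (Homo sapiens) (on this read-out lower numbers stand for stronger inhibition and higher numbers for weaker inhibition), compound 1 gives 60 nM and compound 2 gives 50 nM. Among the compounds with values here, the only measured step, a 1.2-fold lower number from compound 1 to compound 2 (0.08 log units; within the scatter), concerns 4-(trifluoromethyl)phenyl in place of 4-chloro-3-methylphenyl on an aromatic carbon. Compound 2 therefore holds the lower of the two numbers, though within the scatter of compound 1. Compound 3 `Cc1ccc2c(c1)n(C1CCN(CC(O)Cn3nc(-c4ccc(C(F)(F)F)cc4)c4c3CCN(S(C)(=O)=O)C4)CC1)c(=O)n2C` differs from compound 2 elsewhere: a group of 12 heavy atoms (9 carbon, 2 nitrogen, 1 oxygen; one five-membered aromatic ring with 2 hetero atoms, one six-membered aromatic ring of carbon only) in place of a group of 10 heavy atoms (7 carbon, 2 nitrogen, 1 oxygen; one five-membered aromatic ring with 2 hetero atoms, one six-membered aromatic ring of carbon only), on a saturated ring carbon, on a saturated ring carbon. Within the data shown here, no measured step touches this part of the molecule, so the measured step offers no guide to the size or direction of the change. Relative to compound 2, compound 3 is expected to stay close, with a modest loss allowed, estimated at 80 nM (range 25 nM to 300 nM). The step this estimate implies, a 1.6-fold higher number from compound 2 to compound 3 (0.20 log units; within the scatter), is expected to fall near the scatter in this assay.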

Compound 3, half-maximal inhibitory concentration: 30 nM
Compound 3: middle estimate off by 2.7-fold (0.43 log units), on the high side, and the stated range covers the measured number.
By their numbers in this assay, from the lowest: compounds 3, 2 and 1 (each within the scatter of the next).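

In this assay, within the data shown here, the first measured change at this saturated ring carbon, the entering group in place of 2-hydroxy-1H-benzimidazol-1-yl, gives a 1.7-fold lower number from compound 2 to compound 3 (0.22 log units; within the scatter), so this position accepts the larger group with no change beyond the scatter. The entering group has 0 hydrogen-bond donors where the leaving group has 1, and 12 heavy atoms against 10 heavy atoms, so for this pair the donor is not required to keep the number in this range. No available evidence bears on the reason for this tolerance.

The compounds shown leave open how an amine or a carboxylic acid at this position would read out. They also leave open whether the entering group would behave the same alongside the 4-chloro-3-methylphenyl of compound 1.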